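A few compounds are considered here, and "the series" means these few. Any claim that something is new, unique, unknown or untested is made for them only; others in the source may bear on it.

Three analogues built on the same core have been measured in a functional assay on MDA-MB-468 cells (Homo sapiens) for inhibition, read by sulforhodamine B assay, with a stated time of 48 h; on this read-out lower numbers stand for stronger inhibition of growth and higher numbers for weaker inhibition of growth. Compound 1 `CCOC(=O)C(=Cc1c(-c2ccccc2)[nH]c2ccccc12)C(=O)OCC` gives 3100 nM. Compound 2 `O=C(/C(=C\c1c(-c2ccccc2)[nH]c2ccccc12)S(=O)(=O)c1ccccc1)c1ccccc1` gives 4200 nM, and compound 3 `COc1ccc2[nH]c(-c3ccccc3)c(C=C(C#N)C#N)c2c1` gives 2100 nM. Compound 2 carries the highest of the three numbers, yet its gaps to both neighbours are within the usual scatter of this assay, so the three compounds cannot be told apart on these data.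

Compound 4 `N#C/C(=C\c1c(-c2ccccc2)[nH]c2ccccc12)S(=O)(=O)c1ccccc1` has not yet been measured. It differs from compound 2 in one place: cyano in place of benzoyl on a double-bonded chain carbon bound to a double-bonded chain carbon and a sulfonyl sulfur. Within the data shown here, since no pair of compounds differing in a single place has been measured, there is no direct step to lean on. Compound 3 carries two cyano groups on its double-bonded chain carbon and gives 2100 nM, which sits in the same narrow band as compound 2; however, compound 3 also carries a methoxy group that compound 2 lacks, so it does not isolate the exchange. On that basis the step from compound 2 to compound 4 is expected to be a 1.4-fold lower number from compound 2 to compound 4 (0.15 log units; within the scatter), small and not beyond the scatter, if anything toward a slightly lower number. Compound 4 is therefore estimated at 3000 nM, in a range from 1200 nM to 7500 nM.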

Compound 4, concentration for 50% growth inhibition: 1900 nM
Compound 4: middle estimate off by 1.6-fold (0.20 log units), on the high side; measured number inside the range.
By their numbers in this assay, from the lowest: compounds 4, 3, 1 and 2 (each within the scatter of the next, the first and the last beyond it).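

Among these compounds, the exchange of benzoyl for cyano, on a double-bonded chain carbon bound to a double-bonded chain carbon and a sulfonyl sulfur, gives the first single-place comparison in this set: in this assay it brings a 2.2-fold lower number from compound 2 to compound 4 (0.34 log units; beyond the scatter) and so shows that the group held at this position can shift the read-out. It also shows that the benzoyl group, with its six-membered aromatic ring and larger count of heavy atoms, is not needed here for growth inhibition, since the smaller cyano group, which has no ring, goes with the stronger inhibition. Why the number moves cannot be said, as nothing available on these compounds bears on the cause.

Going by these compounds, this is a single exchange, made on a compound that keeps its sulfonyl group, so it remains open whether cyano in place of benzoyl would give a similar step in compounds with other groups on that chain carbon. An amine, a carboxylic acid or a longer chain at this place is not among the compounds shown, so how far the number can move here is still unknown.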